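Replacing the dimethylthiophene of compound 1

This account rests on a few compounds, and the source may have more. Where it says the series, first, only, none or still open, it means among the compounds named here.

Going by the values given here, compound 1 `Cc1cc(-c2nc3sc(C)cn3c2/C=N/NC(=N)N)c(C)s1` gives 13500 nM in a functional assay on cells (Cancer cell lines, Homo sapiens) for inhibition (on this read-out lower numbers stand for stronger inhibition of growth and higher numbers for weaker inhibition of growth), and holds the lower of the two numbers known, while compound 2 `Cc1cc(-c2nc3sccn3c2/C=N/NC(=N)N)c(C)s1` gives 30200 nM there. Compound 3 `Cc1cn2c(/C=N/NC(=N)N)c(-c3cccs3)nc2s1` has thiophen-2-yl in place of 2,5-dimethylthiophen-3-yl on an aromatic carbon of the shared core. Hydrogen in place of methyl on an aromatic carbon gave a 2.2-fold higher number from compound 1 to compound 2 (0.35 log units; beyond the scatter) as the only measured step, which bears on this change only indirectly. A modest rise is therefore expected in this assay with a wide margin. The expected size is a 1.9-fold higher number from compound 1 to compound 3 (0.27 log units; within the scatter) on this estimate. Compound 3 is estimated at 25000 nM with an expected range from 10000 nM to 60000 nM at its upper end.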

Compound 3, concentration for total growth inhibition: 18600 nM
The estimate for compound 3 lay 1.3-fold (0.13 log units) above the measured number, and the stated range covers the measured number.
By their numbers in this assay, from the lowest: compounds 1, 3 and 2 (each within the scatter of the next, the first and the last beyond it).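

In this assay, thiophen-2-yl in place of 2,5-dimethylthiophen-3-yl gives a 1.4-fold higher number from compound 1 to compound 3 (0.14 log units; within the scatter), so this position tolerates a switch of thiophene attachment, together with the loss of both thiophene methyl groups, without a readable difference. The earlier step concerned a methyl on the shared core and said nothing about this substituent. Nothing available explains this result. On these data alone, whether a phenyl ring or an amine at this position would stay within the same range remains open, as does whether the thiophene sulfur matters here.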